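The source may report more compounds than this note shows. Statements on the series, on what has been measured and on what is new or still open speak of the compounds shown alone.

Three compounds have so far been measured in a functional assay on K562 cells (Homo sapiens) for inhibition, read by trypan blue exclusion, with a stated time of 72 h; a lower number here means a stronger inhibitor, a higher number a weaker inhibitor:

compound 1, `Cn1c(=O)c(S(=O)(=O)c2ccc(C(=O)O)cc2)cc2cnc(Nc3ccc4[nH]ccc4c3)nc21`, 5000 nM
compound 2, `CCCn1c(=O)c(S(=O)(=O)c2ccc(F)cc2F)cc2cnc(Nc3ccc4[nH]ccc4c3)nc21`, 1000 nM
compound 3, `Cc1cc2cc(Nc3ncc4cc(S(=O)(=O)c5ccc(F)cc5F)c(=O)n(C)c4n3)ccc2[nH]1`, 750 nM

Among these three, compound 1 stands at the top of the range, with the highest number and therefore the weakest inhibition. Compound 2 comes closest to it, yet its lower number lies beyond the usual scatter of this assay, and compound 3 sits further away still, also beyond the scatter. Both of these carry a fluorine-bearing ring where compound 1 carries an acid, though each also differs from compound 1 elsewhere, so no single change can be read off from them.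

Among the compounds with values here, compound 4, `Cn1c(=O)c(S(=O)(=O)c2ccc(F)cc2)cc2cnc(Nc3ccc4[nH]ccc4c3)nc21`, keeps the shared core of compound 1 and alters only one group: fluoro in place of carboxy on an aromatic carbon. A carboxy group, with its hydrogen-bond donor and acceptor, gives way to a single fluorine atom.

Within the data shown here, no directly comparable pair has been measured, so the size of this step is open. Given that compound 2 and compound 3 each show a lower number than compound 1, a move toward stronger inhibition seems more likely than a move away, and a step of the order seen between compound 1 and compound 2 is plausible. Compound 4 is therefore expected to reach about 1200 nM in this assay, within a range from 400 nM to 4000 nM, which corresponds to an estimated step of a 4.2-fold lower number from compound 1 to compound 4 (0.62 log units; beyond the scatter).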

Compound 4, half-maximal inhibitory concentration: 200 nM
The estimate for compound 4 lay 6.0-fold (0.78 log units) above the measured number; measured number below the stated range.
By their numbers in this assay, from the lowest: compound 4; then compounds 3 and 2 (each within the scatter of the next); then compound 1.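

Within the data shown here, replacing the carboxy group with fluoro on the shared core in this assay gives a 25-fold lower number from compound 1 to compound 4 (1.40 log units; beyond the scatter) and is the first change here that can be read on its own. It shows that this spot on the six-membered aromatic ring, para to a large group, strongly affects the result in these cells, since nothing else differs between the two compounds. The change removes a hydrogen-bond donor and acceptor and three heavy atoms, and it puts a single fluorine in their place, so several counted features shift together in this one step. Nothing available here explains why the number moves so far.

The compounds shown leave open whether the gain comes from losing the carboxylic acid or from adding the fluorine, a question that a plain phenyl ring, a chloro group, an amine or an amide at the same spot could help to separate. They also leave open whether the same swap would have a similar effect with a longer chain such as propyl on the shared core, or with a second fluorine on the ring.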